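The compounds below may be only part of what the source reports. "The series", "measured", "known", "first", "only" and "open" are said of these compounds alone.

Measured compounds in a functional assay on HepG2 cells (Homo sapiens) for cytotoxicity, read by MTT assay, with a stated time of 48 h; on this read-out lower numbers stand for stronger inhibition and higher numbers for weaker inhibition:

Compound 1 `Cc1nnc(SCc2ccccc2)n1N1C(=O)c2ccccc2C1=O`: compound 1 gives > 200000 nM, which is a limit of the assay and not a number.
Compound 2 `Cc1nnc(SCc2ccccc2Cl)n1N1C(=O)c2ccccc2C1=O`: compound 2 gives > 200000 nM, again a limit of the assay.
Compound 3 `CCc1nnc(SCC(=O)c2ccccc2)n1N1C(=O)c2ccccc2C1=O`: compound 3 gives > 200000 nM, also a limit of the assay.

Compounds 1 and 2 share one core and differ in a single place, (chloro in place of hydrogen on an aromatic carbon). The step from compound 1 to compound 2 in this assay is a step that the two limits leave unreadable from compound 1 to compound 2, so no direction or size can be read from this pair. Compound 3 has a different core, and the difference between the two cores is not broken down here. What unites all three measured compounds is the limit of > 200000 nM in this assay, at which 3 of the 3 values shown sit.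

Compound 4 `CCc1nnc(SCC(=O)c2ccc(Cl)cc2)n1N1C(=O)c2ccccc2C1=O` has not yet been measured in this assay. It differs from compound 3 by chloro in place of hydrogen on an aromatic carbon. Going by the values given here, this is the same kind of change as the one from compound 1 to compound 2, but not the same: in compound 2 the chloro sits ortho to a large group, while in compound 4 it sits para to a large group.

The step from compound 3 to compound 4 in this assay is expected to be a step that the limit leaves unreadable from compound 3 to compound 4, an expectation that rests on the limit of > 200000 nM in this assay, at which 3 of the 3 values shown sit, and on the unreadable step that the two limits leave unreadable from compound 1 to compound 2. For compound 4 the estimate is therefore 250000 nM, between 100000 nM and 600000 nM, with a high chance that only a limit is reported again.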

Compound 4, half-maximal inhibitory concentration: > 200000 nM
Compound 4: a limit, no number; the forecaster's own chance of this, stated with the estimate: 85%; the middle value does not contradict the limit.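

In this assay compound 4 gives > 200000 nM, which is a limit of the assay and not a number. Going by these compounds alone, compound 3 also stands at a limit, so no step between compound 3 and compound 4 can be read. The compounds shown leave open what number any of them would give in this assay and whether chloro in place of hydrogen changes it, for they share one result: the limit of > 200000 nM in this assay, at which 4 of the 4 values shown sit.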